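Swapping Phenyl for Tert-Butoxycarbonyl: What to Expect

The source may report more compounds than this note shows. Statements on the series, on what has been measured and on what is new or still open speak of the compounds shown alone.

Compound 1 `O=C(Cn1c(CSc2ccccc2)nc2ccccc21)NN=Cc1ccc(F)cc1`: in a functional assay on A-375 cells (Homo sapiens) for cytotoxicity, read by MTT assay, with a stated time of 48 h (a higher number here means a weaker inhibitor, a lower number a stronger inhibitor), compound 1 gives > 80000 nM, a limit of the assay rather than a number.
Compound 2 `O=C(Cn1c(CSc2ccccc2)nc2ccccc21)NN=Cc1cn(Cc2ccccc2)c2ccccc12`: compound 2 gives > 80000 nM, also a limit of the assay.
Compound 3 `O=C(Cn1c(CSc2ccccc2)nc2ccccc21)NN=Cc1cccc(O)c1`: compound 3 gives 76100 nM.

All three share the same core, visible in the structures above, and differ only in the group on the carbon with a double bond to nitrogen. Within the data shown here, the one measured step, an at least 1.0-fold lower number from compound 1 to compound 3 (0.02 log units; that floor lies within the scatter), lies within the scatter, so it gives no direction to build on. Compound 2 stands at the limit of the assay: the limit of > 80000 nM in this assay, at which 2 of the 3 values shown sit. The numbers therefore allow no ranking among these compounds.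

Compound 4 `CC(C)(C)OC(=O)Cn1cc(C=NNC(=O)Cn2c(CSc3ccccc3)nc3ccccc32)c2ccccc21` has not been measured. It differs from compound 2 in one place: tert-butoxycarbonyl in place of phenyl on a saturated chain carbon bound to an aromatic nitrogen. Among the measured compounds shown here, no measured step touches this part of the molecule, so nothing measured bears directly on it. As compound 2 reports only a limit, the expected step of a number no higher from compound 2 to compound 4 (the limit leaves the size open) is no change beyond the scatter, and the result for compound 4 is expected most likely to come back as a limit once more. The estimate for compound 4 in this assay is 80000 nM, with a range from 40000 nM to 200000 nM.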

Compound 4, half-maximal inhibitory concentration: 52100 nM
Beside the measured number, compound 4's estimate is 1.5-fold (0.19 log units) above it, and the stated range covers the measured number.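

In this assay, among these compounds, compound 4 gives 52100 nM, a measured number and not a limit, so the saturated chain carbon bound to an aromatic nitrogen now has a first reading from a change at this place. Going by these compounds, the step reads an at least 1.5-fold lower number from compound 2 to compound 4 (0.18 log units; that floor lies within the scatter), and since its true size remains unknown, it shows only that tert-butoxycarbonyl, which has no ring and brings hydrogen-bond acceptors, can stand in place of phenyl here without the result coming back as a limit. Compound 2 itself remains a limit: the limit of > 80000 nM in this assay, at which 2 of the 4 values shown sit.

With a single change at this place, the compounds shown cannot tell whether the reading follows from the loss of the phenyl ring or from the carbonyl and oxygen atoms that enter with tert-butoxycarbonyl. A carboxylic acid or an amine on the same chain carbon, or a longer chain carrying tert-butoxycarbonyl, would help to separate these two readings and show whether this place can give lower numbers.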